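One Stereocentre Drawn: From Compound 1 to Compound 4

This account rests on a few compounds, and the source may have more. Where it says the series, first, only, none or still open, it means among the compounds named here.

In a physicochemical assay for lipophilicity, at pH 7.4 (a lower number here means a more polar compound, a higher number a more lipophilic compound), compound 1 `CC(C(=O)O)c1nn(Cc2cn3cc(OCC4CC4)c(Cl)cc3n2)c2ccccc2c1=O` gives 2.44, the second highest of the three measured numbers. Compound 3 `CC(C(=O)O)c1nn(Cc2cn3cc(OCC4CC4)c(C(F)(F)F)cc3n2)c2ccccc2c1=O` gives 2.99, and compound 2 `COc1ccc(NC(=O)Cc2nn(CC(=O)O)c(=O)c3ccccc23)c(OC)c1` gives 1.13. Compound 4 `C[C@H](C(=O)O)c1nn(Cc2cn3cc(OCC4CC4)c(Cl)cc3n2)c2ccccc2c1=O` has not yet been measured. Its difference from compound 1 is the two compounds have the same atoms and bonds; at least one stereo element is drawn with a configuration in one of them and without one in the other: 1 of 1 stereo elements differ; a stereocentre at a saturated chain carbon is drawn without a configuration in compound 1 and S in compound 4. The two compounds have the same atoms and bonds, and the stereocentre at a saturated chain carbon is drawn without a configuration in compound 1 and S in compound 4. Among the compounds with values here, the only measured step between closely related compounds is a number 0.55 log units higher from compound 1 to compound 3 (beyond the scatter), with trifluoromethyl in place of chloro on an aromatic carbon. That step changes atoms, not a drawn configuration, so it offers no direct guide here. The expectation therefore starts from compound 1 at 2.44. The expected change, no change at the digits printed from compound 1 to compound 4 (within the scatter), is none beyond the scatter. The estimate for compound 4 is 2.44, with an expected range from 2.14 to 2.74.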

Compound 4, distribution coefficient: 2.39
Compound 4: middle estimate off by 0.05 log units, on the high side; the range from low to high includes it.
By their numbers in this assay, from the lowest: compound 2; then compounds 4 and 1 (each within the scatter of the next); then compound 3.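

The earlier compounds shown here showed only a change of atoms, trifluoromethyl in place of chloro on an aromatic carbon. Within the data shown here, this result is the first to test the saturated chain carbon, where the atoms stay the same and only the drawing of the stereocentre changes. In this assay the outcome is a number 0.05 log units lower from compound 1 to compound 4 (within the scatter), so drawing this centre as S leaves the number indistinguishable from that of the undefined drawing. The whole comparison rests on a single structural difference: the fact that one of compounds 1 and 4 is drawn with a defined configuration and the other without, at the place where they differ.

As far as these compounds go, what the R form at this stereocentre would give remains open. From the compounds shown here alone, it is also open whether an amine or a longer chain at this saturated chain carbon would move the number beyond the scatter.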